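The compounds below may be only part of what the source reports. "The series", "measured", "known", "first", "only" and "open" are said of these compounds alone.

Measured so far in a functional assay on A2780 cells (Homo sapiens) for cytotoxicity, read by MTT assay, with a stated time of 72 h; on this read-out lower numbers stand for stronger inhibition and higher numbers for weaker inhibition:

Compound 1 `Cc1cc(C)cc(C(=O)N(CCCCCC(=O)Nc2ccccc2N)CC(=O)NC2CCCCC2)c1` gives 42000 nM
Compound 2 `Cc1cc(C)cc(C(=O)N(CCCCCC(=O)Nc2ccccc2N)CC(=O)NCc2ccccc2)c1` gives 20900 nM

Within the data shown here, the only measured step is a 2.0-fold lower number from compound 1 to compound 2 (0.30 log units; within the scatter) and it gives compound 1 no clear rank among the two. Compound 3 `Nc1ccccc1NC(=O)CCCCCN(CC(=O)NC1CCCCC1)C(=O)c1ccccc1` differs from compound 1 elsewhere: phenyl in place of 3,5-dimethylphenyl on a carbonyl carbon. Among the measured compounds shown here, no measured step touches that place, and the one step available is small, so no shift beyond the scatter is expected in this assay here. The estimated change is a 1.4-fold lower number from compound 1 to compound 3 (0.15 log units; within the scatter) and no more. For compound 3 the estimated value is 30000 nM with an expected range from 12000 nM to 70000 nM on this read-out.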

Compound 3, half-maximal inhibitory concentration: 181000 nM
Beside the measured number, compound 3's estimate is 6.0-fold (0.78 log units) below it; measured number above the stated range.
By their numbers in this assay, from the lowest: compounds 2 and 1 (each within the scatter of the next); then compound 3.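

In this assay the change from 3,5-dimethylphenyl to phenyl on the carbonyl carbon gives a 4.3-fold higher number from compound 1 to compound 3 (0.63 log units; beyond the scatter) and so weakens inhibition. This is the first step shown that lies beyond the scatter, so this position affects the read-out, and compound 1 keeps the better of the two groups. Nothing available explains the shift.

Open, going by these compounds, is whether a 3-methylphenyl would fall between these two groups, or whether a 3,5-dichlorophenyl would serve as well. Also open, on these data alone, is whether benzoyl costs as much when benzyl replaces cyclohexyl.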